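The source may report more compounds than this note shows. Statements on the series, on what has been measured and on what is new or still open speak of the compounds shown alone.

Three compounds share one core and differ only in the group on a saturated chain carbon bound to a sulfur: compound 1 `Cc1cc(Nc2cc(-c3ccccc3)[nH]n2)n2nc(SCc3c(Cl)cccc3Cl)nc2n1`, compound 2 `Cc1cc(Nc2cc(-c3ccccc3)[nH]n2)n2nc(SCc3ccc(Br)cc3)nc2n1` and compound 3 `Cc1cc(Nc2cc(-c3ccccc3)[nH]n2)n2nc(SCc3cccc(Br)c3)nc2n1`. In an ADME assay on GES1 cells (Homo sapiens) for inhibition, read by MTT assay, with a stated time of 72 h (a lower number here means a stronger inhibitor, a higher number a weaker inhibitor), compound 1 gives 39600 nM. Compound 2 gives 39300 nM in this assay. Compound 3 gives > 50000 nM, which is a limit of the assay and not a number.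

The steps among these compounds are small. Within the data shown here, only one has numbers at both ends, and it is a 1.0-fold lower number from compound 1 to compound 2 (0.00 log units; within the scatter). The two steps that end at the limit give only floors: an at least 1.2-fold higher number from compound 1 to compound 3 (0.10 log units; that floor lies within the scatter), and an at least 1.2-fold higher number from compound 2 to compound 3 (0.10 log units; that floor lies within the scatter).

Compound 4 `Cc1cc(Nc2cc(-c3ccccc3)[nH]n2)n2nc(SCc3nc4ccccc4[nH]3)nc2n1` has not yet been measured. It differs from compound 3 by a larger exchange: 1H-benzimidazol-2-yl in place of 3-bromophenyl on a saturated chain carbon bound to a sulfur. In short, 1H-benzimidazol-2-yl takes the place of 3-bromophenyl. Among the measured compounds shown here, no measured compound carries that group, so the earlier steps are only a loose guide, and the range has to stay wide.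

Going by a 1.0-fold lower number from compound 1 to compound 2 (0.00 log units; within the scatter) and the two floors, no step beyond the scatter is expected in this assay, in either direction. The expected change is an at least 1.1-fold lower number from compound 3 to compound 4 (0.04 log units; that floor lies within the scatter). Compound 4 is expected at about 45000 nM, with an estimated range of 18000 nM to 100000 nM.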

Compound 4, half-maximal inhibitory concentration: 27800 nM
Estimate against measurement, compound 4: 1.6-fold (0.21 log units) above; the range from low to high includes it.
By their numbers in this assay, from the lowest: compounds 4, 2 and 1 (each within the scatter of the next). At a limit, above all of these: compound 3.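

Among these compounds, compound 4 is the first compound here in which the group on the saturated chain carbon bound to a sulfur holds a five-membered aromatic ring with hetero atoms and a hydrogen-bond donor, in place of a halogen-bearing phenyl, and in this assay this large exchange still gives only small steps: a 1.4-fold lower number from compound 2 to compound 4 (0.15 log units; within the scatter), and a 1.4-fold lower number from compound 1 to compound 4 (0.15 log units; within the scatter). The remaining step, an at least 1.7-fold lower number from compound 3 to compound 4 (0.25 log units; that floor lies within the scatter), is only a floor, since one end of it is a limit of the assay and not a number: the limit of > 50000 nM in this assay, at which 1 of the 4 values shown sits. Among the numbers that can be read, compound 1, compound 2 and compound 4 therefore show no step beyond the scatter at this position, even with a group of a quite different kind.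

The compounds shown leave open whether another kind of group at this place, such as an amine, a carboxylic acid or a longer chain, would move the number beyond the scatter in this assay. They also do not separate the hydrogen-bond donor of 1H-benzimidazol-2-yl from its added ring, a question that a 1-methyl-1H-benzimidazol-2-yl group could address.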